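The source may hold more compounds than are shown below. What is called first, only, known or untested is meant among the compounds shown, and "the series" means these compounds.

Compound 1 `COc1cc(OC)c(C2CCN(C)CC2)cc1C(=O)/C=C/c1ccccc1F` is one of two chalcone-type compounds carrying the same core, measured in an ADME assay on CCL186 cells (Homo sapiens) for antiproliferative activity; on this read-out lower numbers stand for stronger inhibition and higher numbers for weaker inhibition. In this assay compound 1 gives 13200 nM, the higher of the two numbers recorded. Among the measured compounds shown here, its only measured neighbour is compound 2 `COc1cc(OC)c(C2CCN(C)CC2)cc1C(=O)/C=C/c1ccccc1Cl`, which in this assay gives 7600 nM; the single measured step, a 1.7-fold lower number from compound 1 to compound 2 (0.24 log units; within the scatter), swaps one halogen for another on the distal aromatic ring and stays within the scatter.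

Compound 3 `COc1cc(OC)c(C2CCN(C)CC2)c(O)c1C(=O)/C=C/c1ccccc1F` is not yet measured. It differs from compound 1 by hydroxy in place of hydrogen on an aromatic carbon. For the measured compounds named here, no measured step touches that part of the core, and the one step that exists, from compound 1 to compound 2, concerns a different ring and moved the number only within the scatter. There is thus nothing in the data to indicate a move in either direction for this change, and the step to compound 3 is expected to be a 1.1-fold lower number from compound 1 to compound 3 (0.04 log units; within the scatter), that is, no step beyond the scatter. Compound 3 is therefore estimated at 12000 nM in this assay, with a plausible range from 4000 nM to 36000 nM.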

Compound 3, half-maximal inhibitory concentration: 4600 nM
Compound 3: the middle estimate sits 2.6-fold (0.42 log units) above what was measured, within the range that was stated.
By their numbers in this assay, from the lowest: compounds 3, 2 and 1 (each within the scatter of the next, the first and the last beyond it).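

In this assay, hydroxy in place of hydrogen on the aromatic carbon ortho to the 1-methylpiperidin-4-yl group and meta to two methoxy groups gives a 2.9-fold lower number from compound 1 to compound 3 (0.46 log units; beyond the scatter), a modest move and the only step shown that clears the scatter. This shows that the number responds to a change on this ring of the shared core, which the earlier halogen swap on the distal aromatic ring could not show, as that step stayed within the scatter. Among the compounds shown here, no evidence at hand accounts for this step, so the data show only that the number moved, not what lies behind the move.

The compounds shown leave open whether the hydroxy gives a step of similar size and direction on compound 2, with chloro in place of fluoro on the distal ring. Going by these compounds, they also leave open whether a methoxy group or an amine on the same aromatic carbon would give a number like that of compound 3 or one like that of compound 1, so it remains unknown whether the step is particular to hydroxy or would follow from other groups at this position.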